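Notes: methyl on a ring hydroxy oxygen in this series

The source may report more compounds than this note shows. Statements on the series, on what has been measured and on what is new or still open speak of the compounds shown alone.

Measured in a functional assay on MDA-MB-231 cells (Homo sapiens) for antiproliferative activity, read by MTT assay, with a stated time of 48 h (a lower number here means a stronger inhibitor of growth, a higher number a weaker inhibitor of growth), so far:
compound 1 `COc1cc2c(cc1O)C(=O)/C(=C/c1cc(OC)c(OC)c(OC)c1)C2`: > 10000 nM, a limit of the assay
compound 2 `COc1cc2c(cc1O)C(=O)/C(=C/c1ccc(OC)c(OC)c1OC)C2`: 2410 nM
compound 3 `COc1cc2c(cc1OC)C(=O)/C(=C/c1cc(OC)c(OC)c(OC)c1)C2`: > 10000 nM, a limit of the assay

Compound 3 is compound 1 with methyl in place of hydrogen on an oxygen on an aromatic ring. The step that the two limits leave unreadable from compound 1 to compound 3 cannot be sized, because of the limit of > 10000 nM in this assay, at which 2 of the 3 values shown sit. Within the data shown here, compound 2 is made of the same atoms as compound 1 joined differently; the difference between the two cores is not broken down here, and compound 2 holds the only number in this assay.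

Compound 4 `COc1cc2c(cc1OC)C(=O)/C(=C/c1ccc(OC)c(OC)c1OC)C2` is not yet measured. It is compound 2 with methyl in place of hydrogen on an oxygen on an aromatic ring, the same change as from compound 1 to compound 3, at the same place. The expected step of a 1.7-fold higher number from compound 2 to compound 4 (0.22 log units; within the scatter) is set beside a step that the two limits leave unreadable from compound 1 to compound 3, which gives no readable size, so the expectation rests on compound 2 with 2410 nM as the only anchor, with wide bounds. Compound 4 is estimated at 4000 nM, between 1500 nM and 12000 nM.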

Compound 4, concentration for 50% growth inhibition: > 10000 nM
Compound 4 was reported as a limit; the forecaster's own chance of this, stated with the estimate: 35%; middle value at least 2.5-fold (0.39 log units) away from the limit.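

In this assay, hydroxy to methoxy on the core of compound 2 gives an at least 4.1-fold higher number from compound 2 to compound 4 (0.61 log units; beyond the scatter), and this size is only a floor for the real step. Compound 4 gives > 10000 nM, which is a limit of the assay and not a number. The same change on the core of compound 1 cannot be read, so the result shows a loss of growth inhibition on one core only and does not show whether the step carries over to the other core or matches it in size: the limit of > 10000 nM in this assay, at which 3 of the 4 values shown sit.

The compounds shown hold only hydrogen or methyl on that oxygen, so the effect of a longer chain there, or of a chain ending in an amine or a carboxylic acid, stays open. Among these compounds, with compound 2 as the only compound holding a number in this assay, it also stays open how far the methoxy compounds lie from it.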